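Swapping methoxy for fluoro on a potent receptor binder

A few compounds are considered here, and "the series" means these few. Any claim that something is new, unique, unknown or untested is made for them only; others in the source may bear on it.

Measured compounds:
compound 1 `COc1ccc(Nc2cncc(N3CC4CC(C3)N4)c2)cc1`, 0.0598 nM
compound 2 `Cc1ccc(Nc2ccc(N3CC4CC(C3)N4)nn2)cc1`, 44.3 nM

In an assay on cell membranes for displacement of a labelled ligand from Neuronal acetylcholine receptor; alpha4/beta2 (Rattus norvegicus) (a higher number here means a weaker inhibitor, a lower number a stronger inhibitor), compound 1 gives 0.0598 nM, the lowest number of the two; compound 2 gives 44.3 nM, a far higher number, well beyond the usual scatter. Compound 3 `Fc1ccc(Nc2cncc(N3CC4CC(C3)N4)c2)cc1` is not yet measured. It differs from compound 1 in one spot: fluoro in place of methoxy on an aromatic carbon. Among the measured compounds shown here, nothing among the measured compounds shows such a swap, so the step from compound 1 is expected to be small, at most a modest weakening close to the scatter, a 2.5-fold higher number from compound 1 to compound 3 (0.40 log units; beyond the scatter). Compound 3 is therefore expected to give about 0.15 nM, between 0.03 nM and 0.8 nM.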

Compound 3, inhibition constant: 0.091 nM
Beside the measured number, compound 3's estimate is 1.6-fold (0.22 log units) above it; the range from low to high includes it.
By their numbers in this assay, from the lowest: compounds 1 and 3 (each within the scatter of the next); then compound 2.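

In this assay, the swap at this aromatic carbon, para to a large group, gives a 1.5-fold higher number from compound 1 to compound 3 (0.18 log units; within the scatter). Fluoro can therefore stand in for methoxy here without a change that can be told from repeat scatter, so binding at this level does not depend on the methoxy oxygen or its hydrogen-bond acceptor. Nothing available explains this tolerance. As far as these compounds go, whether this position would also accept an amine, a carboxylic acid or a longer chain such as butoxy remains open.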